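The source may report more compounds than this note shows. Statements on the series, on what has been measured and on what is new or still open speak of the compounds shown alone.

Measured compounds: compound 1 `COc1cc(/C=C/C(=O)c2cccc(NC(=O)c3c(Cl)cccc3Cl)c2)ccc1O` with 53%; compound 2 `COc1cc(/C=C/C(=O)c2cccc(NC(=O)c3cc(Cl)cc(Cl)c3)c2)ccc1O` with 15%; compound 3 `COc1cc(/C=C/C(=O)c2cccc(NC(=O)c3ccc(Cl)cc3Cl)c2)ccc1O` with 29%, all in a functional assay on HUVEC cells (Homo sapiens) for inhibition, tested at 2.5 ug/mL; a higher number here means a stronger effect of the compound at the concentration tested, a lower number a weaker effect.

Compound 3 stands second highest of the three: in this assay it lies between compound 2, a number 14 percentage points higher from compound 2 to compound 3 (beyond the scatter), and compound 1, a number 24 percentage points lower from compound 1 to compound 3 (beyond the scatter). Compound 4 `COc1cc(/C=C/C(=O)c2cccc(NC(=O)C(C)C)c2)ccc1O` differs from it as follows: isopropyl in place of 2,4-dichlorophenyl on a carbonyl carbon. Within the data shown here, none of the measured steps bears directly on this change; the steps among compounds 1, 2 and 3 only move chlorine atoms around the same aromatic ring, and they show that such changes give steps of modest to large size, as a number 38 percentage points lower from compound 1 to compound 2 (beyond the scatter) shows. Among the measured compounds shown here, since no measured step removes the ring entirely, the step is expected to be a number 9 percentage points lower from compound 3 to compound 4 (within the scatter), most likely downward. Compound 4 is therefore estimated at 20%, within 2% to 45%.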

Compound 4, a percentage reported as inhibition, at one concentration (the size of the read-out at that concentration, not a potency): 11%
Compound 4: the middle estimate sits 9 percentage points above what was measured, within the range that was stated.
By their numbers in this assay, from the lowest: compounds 4 and 2 (each within the scatter of the next); then compound 3; then compound 1.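

In this assay, isopropyl on the carbonyl carbon is the first change shown that removes the aromatic ring, and it gives a number 18 percentage points lower from compound 3 to compound 4 (beyond the scatter) and a number 42 percentage points lower from compound 1 to compound 4 (beyond the scatter). Against the 3,5-dichlorophenyl group, the same change gives a number 4 percentage points lower from compound 2 to compound 4 (within the scatter), so among these compounds the dichlorophenyl ring raises the read-out over isopropyl only with its chlorine atoms placed as in compound 1 and compound 3. No evidence is available to explain this difference.

Going by these compounds, what an unsubstituted phenyl, a longer chain or an amine would give at this carbonyl carbon stays open. So does whether one chlorine atom alone would keep any of the effect seen with compound 1.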